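The source may hold more compounds than are shown below. What is called first, only, known or untested is meant among the compounds shown, and "the series" means these compounds.

Working notes on the series. Compound 1 `CCCCCCCCCCCCCCCCNc1nc(=O)c2ncn([C@@H]3O[C@H](CO)[C@@H](O)[C@H]3O)c2c(=O)[nH]1`, compound 2 `CCCCCCCCCCCCCCCCCCNc1nc(=O)c2ncn([C@@H]3O[C@H](CO)[C@@H](O)[C@H]3O)c2c(=O)[nH]1` and compound 3 `CCCCCCCCCCNc1nc(=O)c2ncn([C@@H]3O[C@H](CO)[C@@H](O)[C@H]3O)c2c(=O)[nH]1` share one core and differ only in the length of the saturated chain. In an assay on isolated protein for inhibition of ATP-dependent RNA helicase SUPV3L1, mitochondrial (Homo sapiens) (on this read-out higher numbers stand for weaker inhibition and lower numbers for stronger inhibition), compound 1 gives > 500 ug/mL, which is a limit of the assay and not a number. Compound 2 gives > 500 ug/mL in this assay, again a limit. Compound 3 gives > 500 ug/mL in this assay, also a limit. Compound 1 and compound 2 differ by ethyl in place of hydrogen on a saturated chain carbon, ten or more bonds along the chain from a nitrogen on an aromatic ring, and the step that the two limits leave unreadable from compound 1 to compound 2. Compound 1 and compound 3 differ by hydrogen in place of hexyl on a saturated chain carbon, ten or more bonds along the chain from a nitrogen on an aromatic ring; the step that the two limits leave unreadable from compound 1 to compound 3, as does a step that the two limits leave unreadable from compound 2 to compound 3. Within the data shown here, no step in this set has a readable size, since (the limit of > 500 ug/mL in this assay, at which 3 of the 3 values shown sit).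

Compound 4 `CCCCCCCCCCCCNc1nc(=O)c2ncn([C@@H]3O[C@H](CO)[C@@H](O)[C@H]3O)c2c(=O)[nH]1` is not yet measured in this assay. It differs from compound 3 by ethyl in place of hydrogen on a saturated chain carbon, ten or more bonds along the chain from a nitrogen on an aromatic ring, the same change as from compound 1 to compound 2, at the same place. Beside a step that the two limits leave unreadable from compound 1 to compound 2, the step that the limit leaves unreadable from compound 3 to compound 4 is expected to be small, resting on (the limit of > 500 ug/mL in this assay, at which 3 of the 3 values shown sit). Compound 4 is expected to give about 600 ug/mL in this assay, estimated between 250 ug/mL and 2000 ug/mL, most likely reported only as a limit.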

Compound 4, half-maximal inhibitory concentration: > 500 ug/mL
Compound 4 gave a limit, no number; the forecaster's own chance of this, stated with the estimate: 85%; the middle value lies beyond the limit too.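

The steps joining compound 4 to compound 1, compound 2 and compound 3 cannot be read, because all four compounds sit at the same limit, which is not a number: the limit of > 500 ug/mL in this assay, at which 4 of the 4 values shown sit.

The compounds shown leave open whether chain length has any bearing on inhibition in this assay, and whether any member of this series gives a measurable value there.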